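Adding a hydroxy group to the ethyl side chain

The compounds below may be only part of what the source reports. "The series", "measured", "known", "first", "only" and "open" are said of these compounds alone.

Compound 2 `CCc1cn(COC(CO)CO)c(=O)[nH]c1=O` carries an ethyl group on the shared core. In a functional assay on Vero cells (Chlorocebus sabaeus) for cytotoxicity (a lower number here means that less compound is tolerated, a higher number that more compound is tolerated), compound 2 reaches only the assay limit of > 410000 nM. Its nearest relative, compound 1 `O=c1ccn(COC(CO)CO)c(=O)[nH]1`, differs by ethyl in place of hydrogen on an aromatic carbon. In this assay compound 1 likewise stops at a limit, > 462000 nM. The step that the two limits leave unreadable from compound 1 to compound 2 therefore cannot be sized. Compound 3 `O=c1[nH]c(=O)n(COC(CO)CO)cc1CCO` brings (hydroxy in place of hydrogen on a saturated chain carbon, two bonds along the chain from an aromatic carbon). Both measured values sit at limits, the limit of > 410000 nM in this assay, at which 1 of the 2 values shown sits, and (the limit of > 462000 nM in this assay, at which 1 of the 2 values shown sits). No change beyond the scatter is expected, so the expected step that the limit leaves unreadable from compound 2 to compound 3 is essentially nil. Compound 3 is expected at 420000 nM, between 200000 nM and 900000 nM, most likely again a limit.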

Compound 3, half-maximal cytotoxic concentration: > 384000 nM
Compound 3: no number, only a limit; the forecaster's own chance of this, stated with the estimate: 85%; the middle value is on the limit's open side.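

Compound 3, like compound 1 and compound 2, stops at a limit in this assay, so the steps among these compounds cannot be read. The compounds shown leave open at what concentration any of them becomes cytotoxic.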